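Methylsulfanyl in Place of Methoxy on a Fused Core

The source may hold more compounds than are shown below. What is called first, only, known or untested is meant among the compounds shown, and "the series" means these compounds.

Measured compounds:
Compound 1 `COc1cc(C)nc2n/c(=N/C(=O)c3c(-c4ccc(Cl)cc4Cl)noc3C)sn12` gives 80.6%
Compound 2 `COc1cc(OC)n2s/c(=N\C(=O)c3c(-c4ccc(Cl)cc4Cl)noc3C)nc2n1` gives 85.6%

Both numbers come from a functional assay on the whole organism for inhibition, with Brassica napus as the target, with a stated time of 72 h, tested at 100 mg/L; on this read-out higher numbers stand for more inhibition of growth at the one concentration tested and lower numbers for less inhibition of growth. Compound 1 has the smaller of the two numbers shown, yet the step of a number 5 percentage points higher from compound 1 to compound 2 (within the scatter) is within the scatter, so the two compounds cannot be told apart on this read-out.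

Compound 3 `CSc1cc(C)nc2n/c(=N/C(=O)c3c(-c4ccc(Cl)cc4Cl)noc3C)sn12` differs from compound 1 in one place: methylsulfanyl in place of methoxy on an aromatic carbon. Within the data shown here, no measured step exchanges methoxy for methylsulfanyl. Among the measured compounds shown here, the only measured step, from compound 1 to compound 2, alters a group on the same ring and stays within the scatter. For the measured compounds named here, nothing among the measured compounds therefore points to a change beyond the scatter for compound 3, and the expected step is a number 0.6 percentage points lower from compound 1 to compound 3 (within the scatter).

Compound 3 is estimated at 80% in this assay, with a range from 68% to 90%.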

Compound 3, percent growth inhibition at one concentration: 62.8%
Compound 3: middle estimate off by 17.2 percentage points, on the high side; the whole stated range lies above it.
By their numbers in this assay, from the lowest: compound 3; then compounds 1 and 2 (each within the scatter of the next).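

In this assay, the carbon carrying methoxy in compound 1 turns out to be sensitive to this change, with methylsulfanyl in its place giving a number 17.8 percentage points lower from compound 1 to compound 3 (beyond the scatter). The only earlier step on this ring stayed within the scatter, so this is the first change shown to move the read-out beyond it. Methoxy and methylsulfanyl share the same counts of heavy atoms and hydrogen-bond acceptors, so exchanging oxygen for sulfur is enough to produce this step, although no measurement here explains it.

Going by these compounds, whether other groups on this carbon, such as an amine or an ethoxy chain, would hold growth inhibition near the level of compound 1 remains open. So does whether the same exchange would produce a similar step on the core of compound 2.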